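Adding a methyl to a compound at the assay limit

The source may report more compounds than this note shows. Statements on the series, on what has been measured and on what is new or still open speak of the compounds shown alone.

- Compound 1 `COc1ccccc1Oc1c(N)nc(-c2ccccc2)nc1Cl`: 7220 nM
- Compound 2 `COc1cccc(-c2nc(N)c(Oc3ccccc3OC)c(Cl)n2)c1`: 24600 nM
- Compound 3 `COc1ccccc1Oc1c(N)nc(-c2ccccc2)nc1OCCO`: > 80000 nM

All three results come from a functional assay on A-375 cells (Homo sapiens) for cytotoxicity, read by CCK-8 assay, with a stated time of 24 h; on this read-out higher numbers stand for weaker inhibition and lower numbers for stronger inhibition. The entry for compound 3, > 80000 nM, is a limit of the assay and not a number. Of the three compounds, it therefore gives the least exact starting point.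

Compound 4 `COc1ccccc1Oc1c(N)nc(-c2cccc(C)c2)nc1OCCO` is compound 3 with methyl in place of hydrogen on an aromatic carbon. The closest measured change is methoxy in place of hydrogen on an aromatic carbon, which gave a 3.4-fold higher number from compound 1 to compound 2 (0.53 log units; beyond the scatter). This is a modest step toward weaker inhibition. The other measured step, an at least 11-fold higher number from compound 1 to compound 3 (1.04 log units; beyond the scatter), is large, but it concerns the 2-hydroxyethoxy group that compounds 3 and 4 already share, so it says little about the new methyl.

Within the data shown here, with one comparable pair as the only guide, no move toward stronger inhibition is expected in this assay. At most, a small shift toward higher numbers is expected, possibly none beyond the scatter, and compound 4 may well be reported only as a limit. The expected change is a step that the limit leaves unreadable from compound 3 to compound 4. For compound 4 the estimated value is 110000 nM, with an expected range from 45000 nM to 250000 nM.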

Compound 4, half-maximal inhibitory concentration: 1380 nM
Compound 4: middle estimate off by 80-fold (1.90 log units), on the high side; measured number outside the range, below it.
By their numbers in this assay, from the lowest: compound 4; then compound 1; then compound 2. At a limit, above all of these: compound 3.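

In this assay, the change from phenyl to 3-methylphenyl gave an at least 57-fold lower number from compound 3 to compound 4 (1.76 log units; beyond the scatter), so a single added methyl at this ring position can shift the result strongly toward stronger inhibition. The methoxy change on this ring went the other way, a 3.4-fold higher number from compound 1 to compound 2 (0.53 log units; beyond the scatter), but that pair carries chloro rather than 2-hydroxyethoxy, so the two steps start from different compounds and the direction of a change here cannot be assumed to carry over from one to the other. The 2-hydroxyethoxy group also does not by itself mean very weak inhibition: compound 4 has that group and still gives 1380 nM.

The true size of the step remains unknown because the entry for compound 3 is a limit of the assay and not a number: the limit of > 80000 nM in this assay, at which 1 of the 4 values shown sits.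

Also open, on these data alone, is whether methyl would bring a similar gain to compound 1, which carries chloro, and what an ethyl group, an amine or a carboxylic acid on this same ring carbon would do in the 2-hydroxyethoxy series.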